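The compounds below may be only part of what the source reports. "The series", "measured", "known", "first", "only" and "open" are said of these compounds alone.

Compound 1 `CC(C)c1ncn2c(S)nncc12` was tested in a functional assay for inhibition, with Homo sapiens as the target; on this read-out lower numbers stand for stronger inhibition and higher numbers for weaker inhibition. In this assay compound 1 gives > 48000 nM, which is a limit of the assay rather than a measured number. Two related compounds have values as well. Compound 2 `CCOC(=O)CSc1nncc2cnc(C)n12` gives 52000 nM in this assay. Compound 3 `CSc1nncc2c(C(C)C)ncn12` gives > 48000 nM in this assay, again a limit. Going by the values given here, compound 1 therefore stands only at a limit, and compound 2 is the single compound of the three with a number. Among the compounds with values here, the one step between measured compounds that differ in a single place is a step that the two limits leave unreadable from compound 1 to compound 3, and its size cannot be read due to the limit of > 48000 nM in this assay, at which 2 of the 3 values shown sit. Compound 4 `Sc1nncc2cncn12` differs from compound 1 by hydrogen in place of isopropyl on an aromatic carbon. Within the data shown here, no measured step bears on this change, and the only step nearby gives no size, so the expectation rests on where compound 1 already stands. In this assay the value for compound 4 is estimated at 60000 nM, with a range from 20000 nM to 200000 nM, which would mean an expected step that the limit leaves unreadable from compound 1 to compound 4.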

Compound 4, half-maximal inhibitory concentration: > 48000 nM
Compound 4 ended at the assay's limit; the forecaster's own chance of this, stated with the estimate: 75%; the middle value is on the limit's open side.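

No step can be read between compound 1 and compound 4, because both stand at a limit rather than a number: the limit of > 48000 nM in this assay, at which 3 of the 4 values shown sit. The compounds shown leave open whether hydrogen in place of isopropyl on that aromatic carbon changes inhibition at all.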